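Ester chain branching: compound 3 to compound 4

This account rests on a few compounds, and the source may have more. Where it says the series, first, only, none or still open, it means among the compounds named here.

compound 1 `CC1=C(C(=O)OCC(C)C)C(c2cccs2)NC(=O)N1C`: 2%
compound 2 `CCOC(=O)C1=C(C)N(C)C(=O)NC1c1ccsc1`: 53%
compound 3 `CCCOC(=O)C1=C(C)N(C)C(=O)NC1c1ccsc1`: 1%

In an assay on membranes from HEK293 cells for displacement of a labelled ligand from adenosine receptor A2b (Homo sapiens), read by scintillation counting, with a stated time of 30 min, tested at 1 uM (a lower number here means less inhibition, a higher number more inhibition at the concentration tested (going by the name of the read-out)), compound 3 gives the lowest of the three numbers; compound 1 lies within the scatter of it, while compound 2 stands well above it. The change to compound 4 `CC1=C(C(=O)OCC(C)C)C(c2ccsc2)NC(=O)N1C` is methyl in place of hydrogen on a saturated chain carbon bound to two saturated chain carbons. For the measured compounds named here, the only measured step on this ester chain, a number 52 percentage points lower from compound 2 to compound 3 (beyond the scatter), shows that lengthening the chain removed most of the inhibition. The same isobutyl ester as in compound 4 is carried by compound 1, which gives 2%. Neither reading gives reason to expect a rise. Because compound 3 gives 1%, the step of a number 2 percentage points higher from compound 3 to compound 4 (within the scatter) is expected to be none beyond the scatter. Compound 4 is estimated at 3%, in the range 0% to 14%.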

Compound 4, a percentage reported as inhibition, at one concentration (the size of the read-out at that concentration, not a potency): 1%
The estimate for compound 4 lay 2 percentage points above the measured number; the range from low to high includes it.
By their numbers in this assay, from the lowest: compounds 3, 4 and 1 (each within the scatter of the next); then compound 2.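

In this assay the step from propyl to isobutyl reads no change at the digits printed from compound 3 to compound 4 (within the scatter) and the change from the ethyl ester reads a number 52 percentage points lower from compound 2 to compound 4 (beyond the scatter) on this chain, so branching does not bring back the inhibition held by the ethyl ester of compound 2. With the isobutyl ester, thiophen-3-yl in place of thiophen-2-yl reads a number 1 percentage points lower from compound 1 to compound 4 (within the scatter) on the saturated ring carbon, so the two thiophene attachments are not told apart on this chain. No evidence on the cause of these readings is at hand.

Open, from the compounds shown here alone, is whether thiophen-2-yl matches thiophen-3-yl on the ethyl ester, and whether a methyl ester or an ester carrying an amine keeps the inhibition.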